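Branching the hydroxyalkyl ester on a shared quinone core

This account rests on a few compounds, and the source may have more. Where it says the series, first, only, none or still open, it means among the compounds named here.

Compound 3 `CCCC(C)(O)CC(=O)O[C@H](CC=C(C)C)C1=CC(=O)c2c(O)ccc(O)c2C1=O` is measured in a functional assay on HeLa cells (Homo sapiens) for cytotoxicity, read by MTT assay; on this read-out lower numbers stand for stronger inhibition and higher numbers for weaker inhibition. In that test compound 3 gives 72000 nM, which is the higher of the two numbers in hand, though the nearest one sits within the scatter. That neighbour is compound 2 `CCCC(O)CC(=O)O[C@H](CC=C(C)C)C1=CC(=O)c2c(O)ccc(O)c2C1=O`, and in this assay compound 2 gives 59300 nM. The step of a 1.2-fold higher number from compound 2 to compound 3 (0.08 log units; within the scatter) came with methyl in place of hydrogen on a saturated chain carbon bound to an oxygen on a saturated carbon and two saturated chain carbons. Compound 1 `CC(C)=CC[C@@H](OC(=O)c1ccoc1)C1=CC(=O)c2c(O)ccc(O)c2C1=O` carries a furan-3-yl group on the carbonyl carbon instead; in this assay compound 1 gives > 100000 nM, which is a limit of the assay and not a number (the limit of > 100000 nM in this assay, at which 1 of the 3 values shown sits). The steps of an at least 1.6-fold lower number from compound 1 to compound 2 (0.22 log units; that floor lies within the scatter) and an at least 1.3-fold lower number from compound 1 to compound 3 (0.14 log units; that floor lies within the scatter) therefore rest on that limit and only set floors.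

Compound 4 `CC(C)=CC[C@@H](OC(=O)CC(C)(O)C(C)C)C1=CC(=O)c2c(O)ccc(O)c2C1=O` is not yet measured. It differs from compound 3 by isopropyl in place of propyl on a saturated chain carbon bound to an oxygen on a saturated carbon and two saturated chain carbons. Going by the values given here, the one measured step at that same carbon, a 1.2-fold higher number from compound 2 to compound 3 (0.08 log units; within the scatter), stayed within the scatter, so a change in the shape of the chain there is expected to give no step beyond the scatter, no change at the digits printed from compound 3 to compound 4 (within the scatter). Compound 4 is thus estimated at 72000 nM, with a range from 30000 nM to 150000 nM.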

Compound 4, half-maximal inhibitory concentration: 27700 nM
Beside the measured number, compound 4's estimate is 2.6-fold (0.41 log units) above it, and the stated range ends above it.
By their numbers in this assay, from the lowest: compound 4; then compounds 2 and 3 (each within the scatter of the next). At a limit, above all of these: compound 1.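

At this saturated chain carbon, the earlier swap of hydrogen for methyl stayed within the scatter, yet in this assay putting isopropyl in place of propyl, with the same atoms joined differently, gives a 2.6-fold lower number from compound 3 to compound 4 (0.41 log units; beyond the scatter) and so shows that the read-out responds to the shape of the group here, and not only to its carbon count. The same 2-hydroxy-2,3-dimethylbutyl ester also stands clear of the less substituted chain of compound 2, with a 2.1-fold lower number from compound 2 to compound 4 (0.33 log units; beyond the scatter) as the step beyond the scatter, whereas compounds 2 and 3 could not be told apart. Against the furan-3-yl ester the step is an at least 3.6-fold lower number from compound 1 to compound 4 (0.55 log units; beyond the scatter) and, unlike the floors for compounds 2 and 3, this floor clears the scatter, though it rests on compound 1, whose entry is a limit and not a number: the limit of > 100000 nM in this assay, at which 1 of the 4 values shown sits.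

On these data alone, whether a bulkier group at this carbon, such as tert-butyl or cyclohexyl, would lower the number further remains open. So does whether the step would survive with an amine or a carboxylic acid in place of the hydroxyl, and nothing here explains why the isopropyl compound differs.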